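Hydroxy in Place of Methylsulfonylmethyl on a Deoxyuridine Core

A few compounds are considered here, and "the series" means these few. Any claim that something is new, unique, unknown or untested is made for them only; others in the source may bear on it.

Compound 1 `COC1=C(OC)/C(=C/Cn2cnc3c(Cl)ncnc32)OC1=O` gives 14000 nM in an ADME assay on L1210/0 cells (Mus musculus) for cytotoxicity, with a stated time of 48 h; on this read-out higher numbers stand for weaker inhibition and lower numbers for stronger inhibition. Compound 2 `CC1=C(c2cn([C@H]3C[C@H](O)[C@@H](CO)O3)c(=O)[nH]c2=O)C(=O)c2ccccc2C1=O` gives 68800 nM in this assay. Compound 3 `CS(=O)(=O)Cc1cn([C@H]2C[C@H](O)[C@@H](CO)O2)c(=O)[nH]c1=O` gives only a limit of the assay, > 200000 nM, in this assay.

Among the compounds with values here, of the three measured compounds, compound 3 is the one for which no number was found, only a limit: it sits at the limit of > 200000 nM in this assay, at which 1 of the 3 values shown sits. Compound 1 and compound 2 each have a number, and compound 3 stands apart from both in that respect alone, since a limit cannot be placed in order against them.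

Compound 4 `O=c1[nH]c(=O)n([C@H]2C[C@H](O)[C@@H](CO)O2)cc1O` is not yet measured. It differs from compound 3 in one place: hydroxy in place of (methylsulfonyl)methyl on an aromatic carbon. Within the data shown here, no step between two measured compounds in this set speaks to this exchange, so there is no measured precedent to lean on. The shared core of compound 3 and compound 4 is the same, and compound 3 shows no activity within the range of this assay.

The account therefore expects compound 4 to stay near the limit, with the step that the limit leaves unreadable from compound 3 to compound 4 taken as none beyond the scatter. The estimate for compound 4 is 300000 nM, within 120000 nM to 1000000 nM.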

Compound 4, half-maximal inhibitory concentration: > 200000 nM
Compound 4 ended at the assay's limit (the forecaster's own chance of this, stated with the estimate: 80%); the middle value does not contradict the limit.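

In this assay compound 4 joins compound 3 at a limit and not at a number, so no step between these two compounds can be read: the limit of > 200000 nM in this assay, at which 2 of the 4 values shown sit.

The compounds shown leave open whether hydroxy in place of (methylsulfonyl)methyl on this aromatic carbon changes cytotoxicity at all, since neither compound gives a number to compare.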